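Swapping a substituted pyridine for phenyl on the ether

This account rests on a few compounds, and the source may have more. Where it says the series, first, only, none or still open, it means among the compounds named here.

Compound 1 `O=C(Nc1cccc(Oc2nccc(C(F)(F)F)c2Cl)c1)C1CCCN(C(=O)c2cc(C(F)(F)F)cc(C(F)(F)F)c2)C1` carries an aryl ether whose outer ring is a 3-chloro-4-(trifluoromethyl)pyridin-2-yl group. In an ADME assay on PC-3 cells (Homo sapiens) for cytotoxicity, read by WST assay, tested at 100 uM (on this read-out higher numbers stand for more inhibition at the one concentration tested (going by the name of the read-out) and lower numbers for less inhibition), compound 1 gives 0%. Two related amides were also measured: compound 2 `N#Cc1cccc(C(=O)N2CCCC(C(=O)Nc3ccc(Cl)cc3)C2)c1` gives 0%, and compound 3 `O=C(Nc1ccc(Cl)cc1)C1CCCN(C(=O)c2cccc(-c3cccs3)c2)C1` gives 4%. Compound 1 thus stands level with compound 2 at the digits shown, the two together being the lowest of the three numbers, and compound 3 sits only slightly apart, within the scatter.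

Compound 4 `O=C(Nc1cccc(Oc2ccccc2)c1)C1CCCN(C(=O)c2cc(C(F)(F)F)cc(C(F)(F)F)c2)C1` differs from compound 1 in one place: phenyl in place of 3-chloro-4-(trifluoromethyl)pyridin-2-yl on an oxygen on an aromatic ring. For the measured compounds named here, only one measured step exists, a number 4 percentage points higher from compound 2 to compound 3 (within the scatter), and it alters a different group at a different place, so it bears on this change only loosely; still, it shows that exchanging one aromatic substituent for another left the read-out within the scatter. Going by the values given here, no measured step touches the ether oxygen. Given that all three measured values lie within the scatter of one another, the step of a number 2 percentage points higher from compound 1 to compound 4 (within the scatter) is expected to stay within the scatter. Compound 4 is therefore estimated at 2%, with a range from 0% to 12%.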

Compound 4, a percentage reported as inhibition, at one concentration (the size of the read-out at that concentration, not a potency): 1%
Estimate against measurement, compound 4: 1 percentage points above; the measured number falls inside the stated range.
By their numbers in this assay, from the lowest: compounds 1, 2, 4 and 3 (each within the scatter of the next).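

For the compounds shown here, putting phenyl in place of 3-chloro-4-(trifluoromethyl)pyridin-2-yl on an oxygen on an aromatic ring in this assay gives a number 1 percentage points higher from compound 1 to compound 4 (within the scatter) and is the first measured change at this place. The outer ring goes from 11 heavy atoms to 6 and loses its ring nitrogen, chlorine and trifluoromethyl group, yet the two numbers stay within the scatter of each other and both lie close to no inhibition. No measured evidence here explains this outcome.

Going by these compounds, it remains open whether any group at this place would lift the number beyond the scatter, such as a saturated cyclohexyl ring or a phenyl ring carrying an amine or a carboxylic acid. The single tested concentration also leaves open how these compounds behave at other concentrations.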